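Hydroxyphenyl-thienylpyridines: a second para-hydroxyl placement

The source may hold more compounds than are shown below. What is called first, only, known or untested is meant among the compounds shown, and "the series" means these compounds.

Working notes on a small set of pyridines carrying two phenolic rings and a thienyl ring. Compound 1 `Oc1ccc(-c2cc(-c3cccs3)cc(-c3ccc(O)cc3)n2)cc1` was tested in an assay on isolated protein for inhibition of DNA topoisomerase 1 (Homo sapiens), with a stated time of 30 min, tested at 20 uM (a lower number here means a weaker effect, a higher number a stronger effect of the compound at the concentration tested), and compound 1 gives 0.9%, that is, essentially no inhibition at the test concentration. Compound 2 `Oc1ccc(-c2cc(-c3ccsc3)cc(-c3ccccc3O)n2)cc1` has no result in this assay: compound 2 is reported as "not determined" (no result reported). Compound 3 `Oc1ccc(-c2cc(-c3ccsc3)cc(-c3cccc(O)c3)n2)cc1` likewise stands without a number: in this assay compound 3 is reported as "not determined" (no result reported), so it cannot be placed relative to compound 1, and the only entry beside it is a second one without a single number.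

Compound 4 `Oc1ccc(-c2cc(-c3ccsc3)cc(-c3ccc(O)cc3)n2)cc1` differs from compound 3 as follows: 4-hydroxyphenyl in place of 3-hydroxyphenyl on an aromatic carbon. Among the compounds with values here, no measured step between compound 3 and compound 4 exists, and with compound 3 itself lacking a number, no step size can be derived; any step is expected to be small, in no firm direction, and likely within the usual scatter of this assay. The nearest measured point is compound 1, which gives 0.9%, and compound 4 is expected to sit close to that. Compound 4 is estimated at 2% in this assay, in the range from -8% to 12%.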

Compound 4, a percentage reported as inhibition, at one concentration (the size of the read-out at that concentration, not a potency): 7.5%
Compound 4: the middle estimate sits 5.5 percentage points below what was measured, and the stated range covers the measured number.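

In this assay, thiophen-3-yl in place of thiophen-2-yl on an aromatic carbon gives a number 6.6 percentage points higher from compound 1 to compound 4 (within the scatter), so with 4-hydroxyphenyl groups on both sides of the shared core, the attachment point of the thienyl ring does not separate the two compounds at the single concentration tested. Within the data shown here, compound 4, at 7.5%, also provides the first number for a thiophen-3-yl member of the set, but the steps from the 2-hydroxyphenyl and 3-hydroxyphenyl compounds to compound 4 cannot be read, so the effect of moving the hydroxyl at the position next to the ring nitrogen remains unknown. No supporting measurement bears on this result, and it offers no explanation for the values.

The compounds shown leave open whether any group at this position would raise inhibition above the level seen here, for example an aminophenyl or carboxyphenyl group in place of 4-hydroxyphenyl. They also leave open whether a longer chain between the phenol and the shared core would alter the read-out.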